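The source may report more compounds than this note shows. Statements on the series, on what has been measured and on what is new or still open speak of the compounds shown alone.

Measured so far:
compound 1 `COc1ccc(C2CC(c3ccc4ccccc4c3)=NN2C2=NC(=O)/C(=C3\C(=O)Nc4ccccc43)S2)cc1` — 870 nM
compound 2 `O=C1N=C(N2N=C(c3ccccc3)CC2c2ccc(Cl)cc2)S/C1=C1/C(=O)Nc2ccccc21` — 270 nM

Both numbers come from a functional assay on cells (Cancer cell lines, Homo sapiens) for cytotoxicity, read by sulforhodamine B assay, with a stated time of 48 h; on this read-out higher numbers stand for weaker inhibition of growth and lower numbers for stronger inhibition of growth. On this read-out compound 2 holds the lowest of the two numbers; compound 1 gives the higher number, and that gap lies beyond the usual scatter. The two compounds differ in two places at once, so no single change can be held responsible for the gap between them.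

Compound 3 `O=C1N=C(N2N=C(c3ccc4ccccc4c3)CC2c2ccc(Cl)cc2)S/C1=C1/C(=O)Nc2ccccc21` is not yet measured. It differs from compound 2 in one place: naphthalen-2-yl in place of phenyl on a carbon with a double bond to nitrogen. Compound 1 carries this same naphthalen-2-yl group yet also a different group on the other ring carbon, so its higher number in this assay is no clean guide. The expectation for compound 3 is a step of a 1.7-fold higher number from compound 2 to compound 3 (0.22 log units; within the scatter) that stays within or just beyond the scatter, leaning toward a somewhat higher number. Compound 3 is therefore estimated at 450 nM, with a range from 150 nM to 1500 nM.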

Compound 3, concentration for 50% growth inhibition: 400 nM
Estimate against measurement, compound 3: 1.1-fold (0.05 log units) above, and the stated range covers the measured number.
By their numbers in this assay, from the lowest: compounds 2 and 3 (each within the scatter of the next); then compound 1.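

In this assay, naphthalen-2-yl in place of phenyl on the carbon with a double bond to nitrogen gives a 1.5-fold higher number from compound 2 to compound 3 (0.17 log units; within the scatter), so at this position the second aromatic ring makes no clear difference. Compound 3 also separates the two differences that were mixed together between compound 1 and compound 2: with naphthalen-2-yl present in both, chloro in place of methoxy on an aromatic carbon gives a 2.2-fold lower number from compound 1 to compound 3 (0.34 log units; beyond the scatter), and of the two single changes only this modest one lies beyond the scatter. No measurement at hand gives a reason for either step.

From the compounds shown here alone, how this position responds to something other than a carbon-only aromatic ring, such as an amine or a longer chain, remains open. So does how fluoro or trifluoromethyl would compare with chloro on that aromatic carbon.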